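A basic chain placed on the phenol oxygen of compound 2

The compounds below may be only part of what the source reports. "The series", "measured", "known", "first", "only" and "open" are said of these compounds alone.

Two measured compounds frame this account. Within the data shown here, compound 1 `CN(C)CCN1CCCN(C(=O)c2ccc(NC(=O)c3ccccc3-c3ccccc3)cc2)c2ccsc21` is the one for which a number exists: in an assay on CHO cells for inhibition of Vasopressin V2 receptor (Homo sapiens), read by radioligand binding (on this read-out higher numbers stand for weaker inhibition and lower numbers for stronger inhibition), compound 1 gives 80 nM. Compound 2 `O=C(Nc1ccc(C(=O)N2CCCCc3sccc32)cc1O)c1ccccc1-c1ccccc1` stands apart, and its entry in this assay, < 10 nM, is a limit of the assay rather than a number, as the limit of < 10 nM in this assay, at which 1 of the 2 values shown sits, records. Compound 2 therefore sits at the strong end of what has been seen so far, while compound 1 sits at the weaker end; nothing more precise can be said of the distance between them.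

Compound 3 `CN1CCCN(CCCOc2cc(C(=O)N3CCCCc4sccc43)ccc2NC(=O)c2ccccc2-c2ccccc2)CC1` is not yet measured. It differs from compound 2 in one place: 3-(4-methyl-1,4-diazepan-1-yl)propyl in place of hydrogen on an oxygen on an aromatic ring. Read one bond further out, the change is hydroxy to 3-(4-methyl-1,4-diazepan-1-yl)propoxy. Among the measured compounds shown here, no step between two measured compounds is available to calibrate it. The author expects the step of an at least 1.2-fold higher number from compound 2 to compound 3 (0.07 log units; that floor lies within the scatter) in this assay to be modest and toward weaker inhibition, though not clearly beyond the scatter. For compound 3 the estimate in this assay is 12 nM, within a range from 3 nM to 50 nM.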

Compound 3, half-maximal inhibitory concentration: 2 nM
Estimate against measurement, compound 3: 6.0-fold (0.78 log units) above; measured number outside the range, below it.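

In this assay compound 2 stands at < 10 nM, which is a limit and not a number. Among these compounds, compound 3 gives 2 nM, yet no step from compound 2 to compound 3 can be read, because of that entry: the limit of < 10 nM in this assay, at which 1 of the 3 values shown sits. Left open is how far, and in which direction, the 3-(4-methyl-1,4-diazepan-1-yl)propyl chain moves the value.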